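The source may report more compounds than this note shows. Statements on the series, on what has been measured and on what is new or still open speak of the compounds shown alone.

Compound 1 `O=C(N/N=C/c1ccc(O)cc1)c1cnccn1`: 43.1%
Compound 2 `COc1ccc(/C=N/NC(=O)c2cnccn2)cc1OC`: 51.3%
Compound 3 `O=C(N/N=C/c1ccccc1)c1cnccn1`: 21.7%

Of the compounds shown here, three on a shared core have been measured in a functional assay on the whole organism (strain Swiss) for inhibition, with Mus musculus as the target, with stated times of 40 min and 6 h, at a dose of 100 mg/kg by the oral route; a lower number here means less inhibition, a higher number more inhibition at the dose given (going by the name of the read-out). Compound 1 gives 43.1% and stands second highest of the three numbers. Its nearest neighbour is compound 2, which gives 51.3%, a gap that lies within the scatter of this assay, so the two cannot be ordered. Furthest from it is compound 3 with 21.7%, and the single step that separates them, hydrogen in place of hydroxy on an aromatic carbon, gives a number 21.4 percentage points lower from compound 1 to compound 3 (beyond the scatter), a modest change that lies beyond the scatter.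

Compound 4 `O=C(N/N=C/c1ccc(F)cc1)c1cnccn1` has not yet been measured. It differs from compound 1 by fluoro in place of hydroxy on an aromatic carbon. Among the compounds with values here, the only measured step that bears on this change is the one from compound 1 to compound 3, which also removes the hydroxy and lowered the inhibition modestly. The fluoro that enters, like the hydrogen in compound 3, carries no hydrogen-bond donor and no hydrogen-bond acceptor, so a downward step of similar size is expected, with wide uncertainty. Compound 4 is therefore estimated at 28%, within 12% to 45%, a step of a number 15.1 percentage points lower from compound 1 to compound 4 (beyond the scatter).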

Compound 4, a percentage reported as inhibition, in the whole organism at one dose (the size of the read-out at that dose, not a potency): 24.5%
The estimate for compound 4 lay 3.5 percentage points above the measured number; the measured number falls inside the stated range.
By their numbers in this assay, from the lowest: compounds 3 and 4 (each within the scatter of the next); then compounds 1 and 2 (each within the scatter of the next).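

In this assay, a second group put in place of the hydroxy on the aromatic carbon para to a large group also lowers the number: fluoro gives a number 18.6 percentage points lower from compound 1 to compound 4 (beyond the scatter), while the earlier step to hydrogen gave a number 21.4 percentage points lower from compound 1 to compound 3 (beyond the scatter). The lower number at this position is thus no longer tied to hydrogen alone, and the direct comparison of the two replacements gives a number 2.8 percentage points higher from compound 3 to compound 4 (within the scatter), so compounds 3 and 4 cannot be ordered and this read-out does not separate fluoro from hydrogen here. Across these three compounds the drop goes with losing the hydroxy, whichever of the two groups enters, but nothing available gives a reason for this.

Within the data shown here, it remains open whether the hydroxy is the only group at this position that keeps the higher number, or whether an amine, a carboxylic acid or a single methoxy would stand with compound 1 rather than with compounds 3 and 4. Compound 2 differs from compound 1 in more than one place, so it cannot settle what a methoxy alone would do at this position.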